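Replacing the side group of compound 3

This account rests on a few compounds, and the source may have more. Where it says the series, first, only, none or still open, it means among the compounds named here.

Measured in an ADME assay on L02 cells (Homo sapiens) for cytotoxicity, read by MTT assay (a higher number here means a weaker inhibitor, a lower number a stronger inhibitor), each value a limit:
Compound 1 `C=CCOc1cc(/C=C/C(=O)c2ccc(OC)c3c2OC(C)(C)C=C3)ccc1OC`: > 20000 nM
Compound 2 `COc1ccc(/C=C/C(=O)c2ccc(OC)c3c2OC(C)(C)C=C3)cc1OC(=O)CCl`: > 10000 nM
Compound 3 `COc1ccc(/C=C/C(=O)c2ccc(OC)c3c2OC(C)(C)C=C3)cc1OC(=O)c1ccco1`: > 10000 nM

Compound 3 gives > 10000 nM, a limit and not a number. It stands at the limit of > 10000 nM in this assay, at which 2 of the 3 values shown sit. Compound 4 `COc1ccc(/C=C/C(=O)c2ccc(OC)c3c2OC(C)(C)C=C3)cc1CS(C)(=O)=O` puts (methylsulfonyl)methyl in place of ((furan-2-yl)carbonyl)oxy on an aromatic carbon. Within the data shown here, two measured steps bear on this change: a step that the two limits leave unreadable from compound 1 to compound 3 and a step that the two limits leave unreadable from compound 2 to compound 3. Neither has a readable size, so neither gives a direction. No step beyond the scatter, up or down, is therefore expected in this assay, and the estimated step is a step that the limit leaves unreadable from compound 3 to compound 4. For compound 4 the estimated value is 15000 nM, with an expected range from 6000 nM to 40000 nM.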

Compound 4, half-maximal inhibitory concentration: > 10000 nM
Compound 4 gave a limit, no number; the forecaster's own chance of this, stated with the estimate: 80%; the middle value is on the limit's open side.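

Among these compounds, compound 1, compound 2, compound 3 and compound 4 all give limits, not numbers, in this assay, and no step to compound 4 can be read. On these data alone, whether changing the side group shifts the true half-maximal inhibitory concentration at all stays open.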